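Swapping methyl for methoxy on compound 3

A few compounds are considered here, and "the series" means these few. Any claim that something is new, unique, unknown or untested is made for them only; others in the source may bear on it.

Values measured so far in a functional assay on KB cells (Homo sapiens) for antiproliferative activity, read by sulforhodamine B assay, with a stated time of 3 days (a higher number here means that more compound is needed for the effect, a lower number that less compound is needed), are these
- Compound 1 `CCC1=C(O)c2c(oc(-c3ccccc3)cc2=O)C(CC)(CC)C1=O` gives > 236 uM as a limit of the assay
- Compound 2 `CCC1=C(O)c2c(oc(-c3ccccc3OC)cc2=O)C(CC)(CC)C1=O` gives 40.8 uM as its value
- Compound 3 `CCC1=C(O)c2c(oc(-c3ccc(C)c(F)c3)cc2=O)C(CC)(CC)C1=O` gives 28.1 uM as its value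

Among the compounds with values here, compound 3 stands level with compound 2, the only other compound with a measured number, and the gap (a 1.5-fold lower number from compound 2 to compound 3 (0.16 log units; within the scatter)) lies within the scatter. Compound 4 `CCC1=C(O)c2c(oc(-c3ccc(OC)c(F)c3)cc2=O)C(CC)(CC)C1=O` carries methoxy in place of methyl on an aromatic carbon, ortho to a fluoro group and para to a large group (methoxy in place of methyl on an aromatic carbon). Within the data shown here, no measured step makes this exact swap. The nearest are methoxy in place of hydrogen (an at least 5.7-fold lower number from compound 1 to compound 2 (0.76 log units; beyond the scatter)) and the change to the 3-fluoro-4-methylphenyl group (an at least 8.3-fold lower number from compound 1 to compound 3 (0.92 log units; beyond the scatter)). Each lies beyond the scatter, yet they end within the scatter of each other. No step beyond the scatter is therefore expected in this assay, in either direction, and the expected step is small (a 1.1-fold higher number from compound 3 to compound 4 (0.03 log units; within the scatter)). The estimated value for compound 4 is 30 uM (expected range 12 uM to 75 uM).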

Compound 4, concentration for half-maximal effect: 26.7 uM
The estimate for compound 4 lay 1.1-fold (0.05 log units) above the measured number, within the range that was stated.
By their numbers in this assay, from the lowest: compounds 4, 3 and 2 (each within the scatter of the next). At a limit, above all of these: compound 1.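

Methoxy in place of methyl on this aromatic carbon, ortho to a fluoro group, leaves the number in this assay level within the scatter (a 1.1-fold lower number from compound 3 to compound 4 (0.02 log units; within the scatter)). Compound 4 also stands level with compound 2 (a 1.5-fold lower number from compound 2 to compound 4 (0.18 log units; within the scatter)), and it keeps the clear separation from compound 1 (an at least 8.8-fold lower number from compound 1 to compound 4 (0.94 log units; beyond the scatter)). That last step gives only a minimum size, since compound 1 gives a limit: the limit of > 236 uM in this assay, at which 1 of the 4 values shown sits.

Going by these compounds, whether the fluoro group contributes to this level stays open. So does the effect of an amine, a carboxylic acid or a longer chain such as ethoxy at this position.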